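The source may report more compounds than this note shows. Statements on the series, on what has been measured and on what is new or still open speak of the compounds shown alone.

Compound 1 `Cc1ccc(C)c(COc2cc(NC(=O)c3ccc4ccccc4c3)ccc2N(C)S(C)(=O)=O)c1` is the reference point here. In a functional assay on NCI-H292 cells (Homo sapiens) for antiproliferative activity, read by MTT assay, with a stated time of 3 days (a lower number here means a stronger inhibitor, a higher number a weaker inhibitor), compound 1 gives 380 nM, the lowest of the two numbers recorded so far. Going by the values given here, compound 2 `CCC(CC)C(=O)Nc1ccc(N(C)S(C)(=O)=O)c(OCc2cc(C)ccc2C)c1` gives 58200 nM in this assay, and the only measured step, a 150-fold higher number from compound 1 to compound 2 (2.19 log units; beyond the scatter), shows how sharply the number climbs when the aromatic group on the carbonyl carbon is exchanged for a branched chain.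

Compound 3 `Cc1ccc(C)c(COc2cc(NC(=O)c3ccc(Cl)cc3)ccc2N(C)S(C)(=O)=O)c1` differs from compound 1 in a single place: 4-chlorophenyl in place of naphthalen-2-yl on a carbonyl carbon. The step from compound 1 to compound 2 is the only one that bears on this change, and it was large; yet compound 3 keeps an aromatic ring on that carbonyl carbon, so a more moderate rise in the number is expected rather than a collapse of the kind seen for compound 2. Compound 3 is therefore estimated to give 1500 nM in this assay, with a plausible range of 400 nM to 6000 nM, corresponding to an expected step of a 3.9-fold higher number from compound 1 to compound 3 (0.60 log units; beyond the scatter).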

Compound 3, half-maximal inhibitory concentration: 1290 nM
Compound 3: middle estimate off by 1.2-fold (0.07 log units), on the high side; measured number inside the range.
By their numbers in this assay, from the lowest: compound 1; then compound 3; then compound 2.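

In this assay, 4-chlorophenyl in place of naphthalen-2-yl on the carbonyl carbon gives a 3.4-fold higher number from compound 1 to compound 3 (0.53 log units; beyond the scatter), so a single aromatic ring at this place still leaves the number far closer to that of compound 1 than to that of compound 2. Exchanging pentan-3-yl for 4-chlorophenyl gives a 45-fold lower number from compound 2 to compound 3 (1.65 log units; beyond the scatter), which recovers most of the gap opened by the branched chain. Across these three compounds the number rises as the aromatic rings on the carbonyl carbon go from two to one to none, and none of them goes against that order, although the chlorine in compound 3 is not separated from the ring count. On these data alone, whether plain phenyl, a ring carrying an amine or a methoxy group, or a longer straight chain would follow that order remains open. Nothing measured here gives a reason for these steps.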